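Ethoxycarbonylamino substitution on the pyrimidine–pyridine pair

A few compounds are considered here, and "the series" means these few. Any claim that something is new, unique, unknown or untested is made for them only; others in the source may bear on it.

The series is followed in a functional assay on the whole organism for inhibition, with Rattus norvegicus as the target, with stated times of 1 h and 3.5 h, at a dose of 100 mg/kg by the oral route; a lower number here means less inhibition, a higher number more inhibition at the dose given (going by the name of the read-out). Within the data shown here, compound 1 `c1cc(-c2ccncn2)ccn1` gives 45% in this assay, the higher of the two numbers so far. Among the measured compounds shown here, compound 2 `Nc1nccc(-c2cccnc2)n1` gives 32% in this assay, a result lower than that of compound 1 by more than the usual scatter; the two differ in more than one place, so the pair gives no single step.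

Compound 3 `CCOC(=O)Nc1nccc(-c2ccncc2)n1` differs from compound 1 by (ethoxycarbonyl)amino in place of hydrogen on an aromatic carbon, the new group sitting on an aromatic carbon of a six-membered aromatic ring with 2 nitrogen, between two ring nitrogen atoms. For the measured compounds named here, no measured step of this kind exists in the set. The change from compound 1 to compound 3 is expected to be small, with no clear direction beyond the scatter, as a number 5 percentage points lower from compound 1 to compound 3 (within the scatter). For compound 3 in this assay the estimate is 40%, within 20% to 62%.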

Compound 3, a percentage reported as inhibition, in the whole organism at one dose (the size of the read-out at that dose, not a potency): 31%
Compound 3: middle estimate off by 9 percentage points, on the high side, within the range that was stated.
By their numbers in this assay, from the lowest: compounds 3 and 2 (each within the scatter of the next); then compound 1.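

In this assay, the step at the aromatic carbon between two ring nitrogen atoms is a number 14 percentage points lower from compound 1 to compound 3 (beyond the scatter) and gives the series its first reading of a change in one place. The step is modest: with (ethoxycarbonyl)amino on this carbon, compound 3 still gives 31% at the dose given, so inhibition persists, but the group brings no gain over hydrogen. Nothing available accounts for the fall.

Going by these compounds, whether the fall belongs to the whole (ethoxycarbonyl)amino group or to one part of it remains open, and a methylamino or acetylamino group at the same carbon of the core of compound 1 would separate these readings. Also open, on these data alone, is whether a substituent elsewhere on the core of compound 1, such as a methyl group, would give a different step.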